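This account rests on a few compounds, and the source may have more. Where it says the series, first, only, none or still open, it means among the compounds named here.

Measured compounds:
compound 1 `Nc1ccccc1NC(=O)c1ccc(COCNc2nc(Nc3ccccc3)c3ncn(C4CCCC4)c3n2)cc1` — 37.5%
compound 2 `CCCCn1cnc2c(Nc3ccccc3)nc(NCOCc3ccc(/C=C/C(=O)Nc4ccccc4N)cc3)nc21` — 27.9%

In a functional assay on HepG2 cells (Homo sapiens) for antiproliferative activity, read by CCK-8 assay, with a stated time of 72 h, tested at 2 uM (a higher number here means a stronger effect of the compound at the concentration tested, a lower number a weaker effect), compound 1 gives 37.5% and compound 2 gives 27.9%. Compound 2 has the lower of the two numbers, but its distance to compound 1 lies within the scatter, so the two readings cannot be told apart. For the measured compounds named here, compound 1 and compound 2 differ in more than one place, so no single step can be drawn between them.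

Compound 3 `Nc1ccccc1NC(=O)/C=C/c1ccc(COCNc2nc(Nc3ccccc3)c3ncn(C4CCCC4)c3n2)cc1` has not yet been measured in this assay. Its difference from compound 2 is cyclopentyl in place of butyl on an aromatic nitrogen. Going by the values given here, no measured step covers this change, so the expected movement is small: the step of a number 4.1 percentage points higher from compound 2 to compound 3 (within the scatter) is estimated to lie within the scatter, with no clear direction. On that basis compound 3 is expected to give 32% in this assay, between 15% and 50%.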

Compound 3, a percentage reported as inhibition, at one concentration (the size of the read-out at that concentration, not a potency): 2.93%
For compound 3 the middle estimate is 29.1 percentage points above the measured one; measured number below the stated range.
By their numbers in this assay, from the lowest: compound 3; then compounds 2 and 1 (each within the scatter of the next).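

In this assay, the group on the aromatic nitrogen proves not to be a neutral choice: with the 2-((2-aminophenyl)carbamoyl)ethenyl group in place, cyclopentyl in place of butyl brings a number 25 percentage points lower from compound 2 to compound 3 (beyond the scatter). The group on the aromatic carbon also counts: with cyclopentyl held fixed, 2-((2-aminophenyl)carbamoyl)ethenyl in place of (2-aminophenyl)carbamoyl brings a number 34.6 percentage points lower from compound 1 to compound 3 (beyond the scatter). Nothing at hand explains either step.

The compounds shown leave open whether cyclopentyl in place of butyl would move the number in the same way with (2-aminophenyl)carbamoyl on the aromatic carbon, so the two changes cannot yet be separated as independent or linked. They also leave open how a propyl chain, a cyclohexyl ring or a chain ending in an amine would read on the aromatic nitrogen.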